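The compounds below may be only part of what the source reports. "The series", "measured", "known", "first", "only" and "open" are said of these compounds alone.

Compound 1 `C=C[C@@](C)(/C=C/c1ccc(OC)cc1)CCC=C(C)C` is the reference point of this account. In a functional assay on Raji cells (Homo sapiens) for cytotoxicity, with a stated time of 72 h (a lower number here means that less compound is needed, a higher number that more compound is needed for the effect), compound 1 gives only a limit, > 26000 nM, so its true potency is not known as a number. The two other measured compounds offer no sharper anchor. Compound 2 `C=C[C@@](C)(/C=C/c1ccc(O)cc1)CCC1OC1(C)C` reaches only a limit in this assay, > 22500 nM. Compound 3 `C=C[C@@](C)(/C=C/c1ccc(O)cc1)CC/C=C/C(=O)OCc1ccccc1` likewise gives a limit, > 26000 nM. Where compound 1 stands is therefore fixed only by the limit of > 26000 nM in this assay, at which 2 of the 3 values shown sit, while the remaining value rests at the limit of > 22500 nM in this assay, at which 1 of the 3 values shown sits. Going by the values given here, no step between two measured numbers exists in this set, so no measured change can be pointed to.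

Compound 4 `C=C[C@@](C)(/C=C/c1ccc(Nc2ccc(Cl)c(Cl)c2)cc1)CCC=C(C)C` differs from compound 1 by (3,4-dichlorophenyl)amino in place of methoxy on an aromatic carbon. Among the compounds with values here, with no measured step to build on, the expectation leans on the fact that every value so far sits at a limit. The author estimates compound 4 at 12000 nM, between 2000 nM and 60000 nM. That estimate is expected to mean a step of an at least 2.1-fold lower number from compound 1 to compound 4 (0.33 log units; beyond the scatter) toward a lower concentration, though one that may stay within the scatter or end in a further limit.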

Compound 4, half-maximal effective concentration: > 26000 nM
Compound 4: no number, only a limit; the forecaster's own chance of this, stated with the estimate: 55%; middle value at least 2.1-fold (0.33 log units) away from the limit.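

Compound 4 gives only a limit, [ > 26000 nM ]. Compound 1 also gives only a limit, so the step between compound 1 and compound 4 cannot be read. The compounds shown leave open whether any change to the shared core yields an actual number in this assay.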